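Pyrazine for pyridine on the chloro-bearing ring

A few compounds are considered here, and "the series" means these few. Any claim that something is new, unique, unknown or untested is made for them only; others in the source may bear on it.

Measured so far:
Compound 1 `Cc1nc(C(F)(F)F)ccc1C(=O)Nc1ccc(Cl)c(-n2cccn2)c1`: 450 nM
Compound 2 `Cc1nc(C(F)(F)F)ccc1C(=O)Nc1ccc(Cl)c(-c2ccn(C)n2)c1`: 550 nM
Compound 3 `Cc1nc(C(F)(F)F)ccc1C(=O)Nc1ccc(Cl)c(-c2cccnc2)c1`: 10000 nM

All three numbers come from an assay on C3H 10T1/2 cells for inhibition of Sonic hedgehog protein (Mus musculus), read by a luciferase reporter; a lower number here means a stronger inhibitor, a higher number a weaker inhibitor. Compound 3 gives the highest number of the three: the step of a 22-fold higher number from compound 1 to compound 3 (1.35 log units; beyond the scatter) and the step of an 18-fold higher number from compound 2 to compound 3 (1.26 log units; beyond the scatter) are both large, while a 1.2-fold higher number from compound 1 to compound 2 (0.09 log units; within the scatter) stays within the scatter. Compound 4 `Cc1nc(C(F)(F)F)ccc1C(=O)Nc1ccc(Cl)c(-c2cnccn2)c1` arises from compound 3 by pyrazin-2-yl in place of pyridin-3-yl on an aromatic carbon. Going by the values given here, no measured step swaps one six-membered ring for another, so the two large steps only show that compound 3 sits far from compounds 1 and 2. The change is therefore expected to give a number close to that of compound 3, with the estimated step of a 1.3-fold lower number from compound 3 to compound 4 (0.10 log units; within the scatter). Compound 4 is thus expected to give about 8000 nM in this assay, in the range 2500 nM to 25000 nM.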

Compound 4, half-maximal inhibitory concentration: 1700 nM
Compound 4: middle estimate off by 4.7-fold (0.67 log units), on the high side, outside the stated range (below it).
By their numbers in this assay, from the lowest: compounds 1 and 2 (each within the scatter of the next); then compound 4; then compound 3.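

In this assay, six-membered aromatic rings at this position are not all alike: pyrazin-2-yl in place of pyridin-3-yl gives a clear gain (a 5.9-fold lower number from compound 3 to compound 4 (0.77 log units; beyond the scatter)). That gain does not fully reach the level of the two pyrazole groups, since pyrazin-2-yl still stands behind 1-methyl-1H-pyrazol-3-yl (a 3.1-fold higher number from compound 2 to compound 4 (0.49 log units; beyond the scatter)) and 1H-pyrazol-1-yl (a 3.8-fold higher number from compound 1 to compound 4 (0.58 log units; beyond the scatter)). Nothing available explains why this ring change matters. Going by these compounds, it remains open how a pyrimidin-5-yl ring would compare, and whether an amine on the pyrazin-2-yl ring would narrow the remaining gap.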